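A Smaller Hydroxyl-Bearing Amide Replaces the Ester Chain

The source may report more compounds than this note shows. Statements on the series, on what has been measured and on what is new or still open speak of the compounds shown alone.

Compound 1 `CCn1c(C(=O)NCCCN(C)C)ccc1C(CC)(CC)c1ccc(OCCC(O)(CC)CC)c(C)c1`: 110 nM
Compound 2 `C#CC(C)OC(=O)c1ccc(C(CC)(CC)c2ccc(OCCC(O)(CC)CC)c(C)c2)n1CC`: > 50000 nM
Compound 3 `CCC(C)C(NC(=O)c1ccc(C(CC)(CC)c2ccc(OCCC(O)(CC)CC)c(C)c2)n1CC)C(=O)OC`: > 50000 nM

In a functional assay on HepG2 cells (Homo sapiens) for antiproliferative activity, read by MTT assay, with a stated time of 48 h (a lower number here means a stronger inhibitor, a higher number a weaker inhibitor), compound 1 gives 110 nM. For compound 2 the assay reports only a limit, > 50000 nM. For compound 3 it likewise reports only a limit, > 50000 nM. Compound 3 therefore sits at the limit of > 50000 nM in this assay, at which 2 of the 3 values shown sit, together with the weakest readings here.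

Compound 4 `CCn1c(C(=O)NC(C)CO)ccc1C(CC)(CC)c1ccc(OCCC(O)(CC)CC)c(C)c1` differs from compound 3 in one place: a group of 4 heavy atoms (3 carbon, 1 oxygen; no ring) in place of a group of 9 heavy atoms (7 carbon, 2 oxygen; no ring), on an amide-type nitrogen. The related measured steps are an at least 450-fold higher number from compound 1 to compound 3 (2.65 log units; beyond the scatter) and an at least 450-fold higher number from compound 1 to compound 2 (2.65 log units; beyond the scatter), both moving away from a small amide substituent into a limit. Compound 4 returns to a small amide bearing a hydroxyl, so a return toward measurable inhibition is expected, though its size cannot be read from a limit. Compound 4 is expected near 3000 nM, within 300 nM to 50000 nM. The expected step is an at least 16-fold lower number from compound 3 to compound 4 (1.22 log units; beyond the scatter).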

Compound 4, half-maximal inhibitory concentration: 43100 nM
Estimate against measurement, compound 4: 14-fold (1.16 log units) below, within the range that was stated.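

Compounds 2 and 3 give only a limit: the limit of > 50000 nM in this assay, at which 2 of the 4 values shown sit. Compound 4 gives a real number, yet the floors an at least 1.1-fold lower number from compound 3 to compound 4 (0.06 log units; that floor lies within the scatter) and an at least 1.1-fold lower number from compound 2 to compound 4 (0.06 log units; that floor lies within the scatter) do not establish a gain beyond the scatter. With 1-(hydroxymethyl)ethyl in place of 3-(dimethylamino)propyl on the amide-type nitrogen, the result is a 390-fold higher number from compound 1 to compound 4 (2.59 log units; beyond the scatter) and so a small amide bearing a hydroxyl does not match compound 1.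

The compounds shown leave open whether the dimethylamino group or the length of the chain matters more. A 3-hydroxypropyl chain or a shorter 2-(dimethylamino)ethyl chain on the same nitrogen would help separate the two.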